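The source may hold more compounds than are shown below. What is called first, only, known or untested is meant among the compounds shown, and "the series" means these compounds.

Measured to date:
compound 1 `S=C(N/N=C/c1cccc2ccccc12)Nc1ccc(Cl)cc1` — 1900 nM
compound 2 `COc1ccccc1NC(=S)N/N=C/c1cccc2ccccc12` — 920 nM

Both numbers come from a functional assay on B16 cells (Mus musculus), read by spectrophotometry, with a stated time of 3 days; a lower number here means a stronger inhibitor, a higher number a weaker inhibitor. Among the compounds with values here, compound 2 holds the lower of the two; its only neighbour is compound 1, and the single step so far, a 2.1-fold lower number from compound 1 to compound 2 (0.31 log units; beyond the scatter), is a modest one.

Compound 3 `S=C(N/N=C/c1cccc2ccccc12)NC1CCCCC1` is not yet measured. It differs from compound 2 in one place: cyclohexyl in place of 2-methoxyphenyl on an amide-type nitrogen. Within the data shown here, the one measured step, a 2.1-fold lower number from compound 1 to compound 2 (0.31 log units; beyond the scatter), swaps one aromatic ring for another on the same nitrogen, so it bears on this change only in showing that substitution on that nitrogen shifts the number by a modest amount. Among the measured compounds shown here, no measured step covers an aromatic ring giving way to a non-aromatic ring at this position, so no direction can be drawn from the series itself.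

On that basis the step in this assay from compound 2 to compound 3 is expected to be small, and a shift either way would not be surprising. The expected step is a 1.5-fold higher number from compound 2 to compound 3 (0.18 log units; within the scatter). For compound 3 the estimated value is 1400 nM, within a range of 500 nM to 4500 nM.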

Compound 3, half-maximal inhibitory concentration: 290 nM
Estimate against measurement, compound 3: 4.8-fold (0.68 log units) above; measured number below the stated range.
By their numbers in this assay, from the lowest: compound 3; then compound 2; then compound 1.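

Cyclohexyl on the amide-type nitrogen gives the lowest number of the three in this assay, with a step of a 3.2-fold lower number from compound 2 to compound 3 (0.50 log units; beyond the scatter) and a larger printed one of a 6.6-fold lower number from compound 1 to compound 3 (0.82 log units; beyond the scatter), so an aromatic ring at this position is not needed for activity in this small set. Until now the position had been probed only with substituted phenyl groups, whereas compound 3 shows that replacing the aromatic ring with a non-aromatic ring of carbon only moves the number further than the swap between the two aromatic groups did, and neither of those aromatic compounds goes against this ordering. Nothing available bears on the origin of this shift.

From the compounds shown here alone, whether any ring is needed on this nitrogen stays open, as a longer chain such as n-hexyl or a branched group such as tert-butyl would test that directly, and a cyclohexyl carrying a hydroxyl or an amine would show whether the ring accepts further substitution. All three compounds share one core, so the reading also remains tied to that core and to this single assay.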